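Swapping a para-hydroxyl for ortho on a triaryl core

A few compounds are considered here, and "the series" means these few. Any claim that something is new, unique, unknown or untested is made for them only; others in the source may bear on it.

Compounds measured so far:
- compound 1, `Oc1ccc(-c2cc(-c3ccc(O)cc3)nc(-c3ccc(O)cc3)c2)cc1`: 5120 nM
- compound 2, `Oc1cccc(-c2cc(-c3cccc(O)c3)nc(-c3ccccc3O)c2)c1`: > 50000 nM
- compound 3, `Oc1cccc(-c2cc(-c3cccc(O)c3)nc(-c3cccc(O)c3)c2)c1`: 3950 nM

In a functional assay on HCT-15 cells (Homo sapiens) for cytotoxicity, read by CCK-8 assay, with a stated time of 4 days (a lower number here means a stronger inhibitor, a higher number a weaker inhibitor), compound 1 gives 5120 nM, the higher of the two numbers shown; compound 3 is nearest, within the scatter. Compound 2 gives only a limit of the assay, > 50000 nM. Within the data shown here, the one measured step, an at least 12-fold lower number from compound 2 to compound 3 (1.10 log units; beyond the scatter), shows the 2-hydroxyphenyl group going with a far higher number, and it sits at the limit of > 50000 nM in this assay, at which 1 of the 3 values shown sits.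

Compound 4, `Oc1ccc(-c2cc(-c3ccccc3O)cc(-c3ccc(O)cc3)n2)cc1`, differs from compound 1 by 2-hydroxyphenyl in place of 4-hydroxyphenyl on an aromatic carbon. This change runs opposite to the measured step, so a large rise in number is expected: a 7.8-fold higher number from compound 1 to compound 4 (0.89 log units; beyond the scatter). Compound 4 is therefore estimated at 40000 nM, between 10000 nM and 150000 nM, with a fair chance that only a limit is reported.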

Compound 4, half-maximal inhibitory concentration: 1920 nM
Beside the measured number, compound 4's estimate is 21-fold (1.32 log units) above it, outside the stated range (below it).
By their numbers in this assay, from the lowest: compound 4; then compounds 3 and 1 (each within the scatter of the next). At a limit, above all of these: compound 2.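

Placed opposite the ring nitrogen, the 2-hydroxyphenyl group goes with a lower number, not a higher one: a 2.7-fold lower number from compound 1 to compound 4 (0.43 log units; beyond the scatter) in this assay. The earlier step, an at least 12-fold lower number from compound 2 to compound 3 (1.10 log units; beyond the scatter), pointed the other way, so this group's influence is not the same everywhere on the shared core. Nothing given here explains the difference.

Compounds 2 and 4 differ in more than one place, so the role of the position cannot be separated from that of the other hydroxyphenyl groups. As far as these compounds go, how a methoxy group or an amine in place of this hydroxyl would behave at this position remains open.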